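Working notes: from compound 2 to compound 4

The source may hold more compounds than are shown below. What is called first, only, known or untested is meant among the compounds shown, and "the series" means these compounds.

Measured so far in a functional assay on OCI-Ly3 cells (Homo sapiens) for inhibition, read by CellTiter-Glo, with stated times of 48 h and 96 h; a lower number here means a stronger inhibitor of growth, a higher number a weaker inhibitor of growth:
- compound 1 `CCC(=O)[C@H](CCCNC(=N)N)NC(=O)[C@@H]1CCCN1C(=O)[C@@H](NC(=O)[C@H](CC(C)C)NC(=O)OCc1ccccc1)C(C)C` gives > 20000 nM
- compound 2 `CC(C)[C@@H](C(=O)N1CCC[C@H]1C(=O)N[C@@H](CCCNC(=N)N)C(=O)CF)N(C)C(=O)OCc1ccccc1` gives > 20000 nM
- compound 3 `CC(C)[C@H](NC(=O)OCc1ccccc1)C(=O)N1CCC[C@H]1C(=O)N(C)[C@@H](CCCNC(=N)N)C(=O)CF` gives "not determined" (no result reported)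

The entries for compound 1 and compound 2 are limits of the assay, not numbers. Compound 3 has no result, so the series offers no measured number yet. The position of compound 2 is therefore (the limit of > 20000 nM in this assay, at which 2 of the 3 values shown sit), and no ranking can be drawn from it.

The next compound is compound 4 `CC(C)[C@H](NC(=O)c1ccccc1)C(=O)N1CCC[C@H]1C(=O)N[C@@H](CCCNC(=N)N)C(=O)CF`. The structural change from compound 2 is benzamido in place of (benzyloxycarbonyl)(methyl)amino on a saturated chain carbon bound to a carbonyl carbon and a saturated chain carbon, which puts benzamido in place of (benzyloxycarbonyl)(methyl)amino on a saturated chain carbon bound to a carbonyl carbon and a saturated chain carbon.

For the measured compounds named here, no step between measured compounds exists to calibrate this change. Going by the values given here, the only anchor is compound 2 at > 20000 nM, which is a limit. In this assay, no shift beyond the usual scatter is expected in either direction, and the expected step is a number no higher from compound 2 to compound 4 (the limit leaves the size open). A report of compound 4 as a limit as well is the likeliest outcome. The estimate for compound 4 is 20000 nM, with the value expected to fall from 6000 nM to 40000 nM.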

Compound 4, concentration for 50% growth inhibition: 660 nM
Beside the measured number, compound 4's estimate is 30-fold (1.48 log units) above it; the measured number lies below the stated range.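

In this assay, for the compounds shown here, compound 4 gives 660 nM, the first measured number, so a group on a saturated chain carbon bound to a carbonyl carbon and a saturated chain carbon can go with measurable growth inhibition on this core. Placing benzamido there in place of (benzyloxycarbonyl)(methyl)amino brings an at least 30-fold lower number from compound 2 to compound 4 (1.48 log units; beyond the scatter), which shows that the series responds strongly to this single change. Compound 2 stands at a limit of the assay and not at a number, so the full size of the step stays open: the limit of > 20000 nM in this assay, at which 2 of the 4 values shown sit.

The change removes the methyl on the nitrogen and the oxygen of the benzyloxycarbonyl unit together and adds the amide hydrogen, so the compounds shown cannot assign the step to any one of these parts. Also open, as far as these compounds go, is how the number would respond to acetamido, which has no aromatic ring, or to phenylacetamido, which puts a carbon into the link to the ring.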